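The source may report more compounds than this note shows. Statements on the series, on what has been measured and on what is new or still open speak of the compounds shown alone.

Of the compounds shown here, three sharing one core have been measured in a functional assay on HepG2 cells (Homo sapiens) for antiproliferative activity, read by CCK-8 assay, with a stated time of 48 h (a higher number here means a weaker inhibitor, a lower number a stronger inhibitor), and they differ in the group on a saturated chain carbon bound to an aromatic carbon. With hydroxy at that carbon, compound 1 `COc1ccc(/C=C\c2cc(OC)c(OC)c(OC)c2)cc1OCc1ccc(CO)cc1` gives 2400 nM. With 3-carboxyazetidin-1-yl there, compound 2 `COc1ccc(/C=C\c2cc(OC)c(OC)c(OC)c2)cc1OCc1ccc(CN2CC(C(=O)O)C2)cc1` gives > 10000 nM, which is a limit of the assay and not a number. With (2-(dimethylamino)ethyl)amino there, compound 3 `COc1ccc(/C=C\c2cc(OC)c(OC)c(OC)c2)cc1OCc1ccc(CNCCN(C)C)cc1` gives 4400 nM. That places it level with the hydroxy compound, the measured step being a 1.8-fold higher number from compound 1 to compound 3 (0.26 log units; within the scatter), and clear of the limit, with an at least 2.2-fold lower number from compound 2 to compound 3 (0.35 log units; beyond the scatter).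

Compound 4 `COc1ccc(/C=C\c2cc(OC)c(OC)c(OC)c2)cc1OCc1ccc(CNCCNC(C)=O)cc1` alters only the end of that chain, with acetamido in place of dimethylamino, two bonds along the chain from an amine nitrogen: acetamido in place of dimethylamino on a saturated chain carbon, two bonds along the chain from an amine nitrogen. Within the data shown here, no measured step makes this exact swap, so the guides are the changes at the chain carbon. Compound 3 kept its number close to that of compound 1, with a 1.8-fold higher number from compound 1 to compound 3 (0.26 log units; within the scatter), while compound 2 shows that this position can also cost activity, with an at least 4.1-fold higher number from compound 1 to compound 2 (0.61 log units; beyond the scatter). Compound 4 keeps the chain of compound 3 up to the amine nitrogen, so a step within the scatter is expected in this assay, with any drift towards a higher number. The expected change is a 1.1-fold higher number from compound 3 to compound 4 (0.06 log units; within the scatter). The estimate for compound 4 is 5000 nM, with an expected range from 2200 nM to 10000 nM.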

Compound 4, half-maximal inhibitory concentration: 6100 nM
The estimate for compound 4 lay 1.2-fold (0.09 log units) below the measured number; the range from low to high includes it.
By their numbers in this assay, from the lowest: compounds 1, 3 and 4 (each within the scatter of the next, the first and the last beyond it). At a limit, above all of these: compound 2.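

In this assay, the end of the chain tolerates a clear change of group: acetamido, with its added carbonyl and amide hydrogen, replaces dimethylamino with a 1.4-fold higher number from compound 3 to compound 4 (0.14 log units; within the scatter), so this assay does not separate the two ends. Yet the acetamido compound is set apart from the hydroxy compound, with a 2.5-fold higher number from compound 1 to compound 4 (0.41 log units; beyond the scatter), which the dimethylamino compound was not, so a small gap from hydroxy appears even though the two chain ends cannot be told apart from each other. The comparison with the 3-carboxyazetidin-1-yl group stays unsettled, with an at least 1.6-fold lower number from compound 2 to compound 4 (0.21 log units; that floor lies within the scatter), and the starting point of that step is a limit of the assay and not a number: the limit of > 10000 nM in this assay, at which 1 of the 4 values shown sits.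

The compounds shown leave open whether any group at this chain end could bring the number below that of the hydroxy compound, since none of the groups here does so beyond the scatter. A primary amine, a carboxylic acid or a morpholine ring at the chain end, or a longer chain between the two nitrogens, would test how far this tolerance reaches.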